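The compounds below may be only part of what the source reports. "The series", "measured", "known", "first", "only" and "open" are said of these compounds alone.

Measured compounds:
Compound 1 `CNC(=O)c1cc(Oc2ccc(NC(=O)c3cc(-c4ccc(Cl)cc4)ncn3)cc2F)ccn1`; in a functional assay on MCF7 cells (Homo sapiens) for cytotoxicity, read by MTT assay, with a stated time of 72 h (a higher number here means a weaker inhibitor, a lower number a stronger inhibitor), compound 1 gives > 100000 nM, a limit of the assay.
Compound 2 `CNC(=O)c1cc(Oc2ccc(NC(=O)c3cc(-c4ccc(Br)cc4)ncn3)cc2F)ccn1`; in this assay compound 2 gives > 100000 nM, also a limit of the assay.
Compound 3 `CCc1ccc(-c2cc(C(=O)Nc3ccc(Oc4ccnc(C(=O)NC)c4)cc3)ncn2)cc1`; in this assay compound 3 gives 6350 nM.

Among the measured compounds shown here, compound 3 holds the only number among the three; the other two values are limits, and the limit of > 100000 nM in this assay, at which 2 of the 3 values shown sit, marks where both sit. For the measured compounds named here, the single step between measured compounds, a step that the two limits leave unreadable from compound 1 to compound 2, runs from one limit to another and its size cannot be read. Compound 4 `CCc1ccc(-c2cc(C(=O)Nc3ccc(Oc4ccnc(C(=O)NC)c4)c(F)c3)ncn2)cc1` differs from compound 3 by fluoro in place of hydrogen on an aromatic carbon. Going by the values given here, no measured step follows this change on its own: compound 1 and compound 2 carry the fluoro but differ from compound 3 elsewhere as well, so their limits cannot be set against the number of compound 3 to yield a size. The account therefore expects a modest step, a 2.4-fold higher number from compound 3 to compound 4 (0.37 log units; beyond the scatter), leaning toward weaker inhibition in this assay. Compound 4 is estimated at 15000 nM, with a range from 4000 nM to 60000 nM.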

Compound 4, half-maximal inhibitory concentration: 7630 nM
Estimate against measurement, compound 4: 2.0-fold (0.29 log units) above, within the range that was stated.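

In this assay, fluoro in place of hydrogen, ortho to the (2-(methylcarbamoyl)pyridin-4-yl)oxy group, now has a step of its own, a 1.2-fold higher number from compound 3 to compound 4 (0.08 log units; within the scatter), so on its own this change shifts nothing that can be told from the scatter. With the fluoro present on both sides, ethyl in place of bromo gives an at least 13-fold lower number from compound 2 to compound 4 (1.11 log units; beyond the scatter) and ethyl in place of chloro gives an at least 13-fold lower number from compound 1 to compound 4 (1.11 log units; beyond the scatter), so among these compounds the large steps go with the ethyl and not with the fluoro. Compound 1 and compound 2 each stand at a limit of the assay: the limit of > 100000 nM in this assay, at which 2 of the 4 values shown sit.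

The compounds shown leave open whether fluoro in place of hydrogen would give so small a step with chloro or bromo in place of the ethyl. They also leave open how a propyl chain, a methoxy group or an amine would read in place of the ethyl.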